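Chloro to fluoro exchange, from compound 2 to compound 3

This account rests on a few compounds, and the source may have more. Where it says the series, first, only, none or still open, it means among the compounds named here.

Two compounds of the series carry numbers in a functional assay on B16-F10 cells (Mus musculus) for antiproliferative activity, read by MTT assay, with a stated time of 48 h; on this read-out higher numbers stand for weaker inhibition and lower numbers for stronger inhibition. In this assay compound 1 `Cc1ncc([N+](=O)[O-])n1CC(=O)NS(=O)(=O)c1ccc(F)cc1` gives 0.35 ug/mL. In this assay, among the measured compounds shown here, compound 2 `O=C(Cc1ccc(F)cc1)NS(=O)(=O)c1ccc(Cl)cc1` gives 6.36 ug/mL, the highest of the two numbers; its gap to compound 1 lies beyond the scatter, and no step between the two is set out, as the structures differ in more than one place. Compound 3 `O=C(Cc1ccc(F)cc1)NS(=O)(=O)c1ccc(F)cc1` awaits measurement. It differs from compound 2 by fluoro in place of chloro on an aromatic carbon. For the measured compounds named here, no measured pair isolates this exchange, so the expectation rests on the change alone. The step of a 1.3-fold higher number from compound 2 to compound 3 (0.10 log units; within the scatter) is expected to stay within the scatter, if anything toward a slightly higher number. Compound 3 is estimated at 8 ug/mL in this assay, with a range from 3 ug/mL to 22 ug/mL.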

Compound 3, half-maximal inhibitory concentration: 4.23 ug/mL
For compound 3 the middle estimate is 1.9-fold (0.28 log units) above the measured one; the measured number falls inside the stated range.
By their numbers in this assay, from the lowest: compound 1; then compounds 3 and 2 (each within the scatter of the next).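

In this assay, among the compounds shown here, this pair gives the first isolated reading of the 4-chlorophenyl to 4-fluorophenyl exchange, with a 1.5-fold lower number from compound 2 to compound 3 (0.18 log units; within the scatter) for fluoro in place of chloro on an aromatic carbon para to a large group. At this position, and on the shared core of compound 2 and compound 3, the assay does not tell the two halogens apart, so either one is accepted here. No further measurement on hand bears on this result.

Only these two halogens are shown at this position, so the reading with an amine, a methoxy group or a carboxylic acid there remains open. From the compounds shown here alone, whether the same exchange would also read within the scatter on the core of compound 1 remains open as well.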